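Methyl for fluoro on the shared core: compound 4

The source may report more compounds than this note shows. Statements on the series, on what has been measured and on what is new or still open speak of the compounds shown alone.

Three compounds have numbers in a functional assay on C6 cells (Rattus norvegicus) for cytotoxicity, read by MTT assay, with a stated time of 24 h; on this read-out lower numbers stand for stronger inhibition and higher numbers for weaker inhibition. Compound 1 `Cc1ccc2oc(-c3ccc(NC(=O)CN4CCN(CCN(C)C)CC4)cc3)nc2c1` gives 1630 nM in this assay. Compound 2 `CN(C)CCN1CCN(CC(=O)Nc2ccc(-c3nc4cc(F)ccc4o3)cc2)CC1` gives 4390 nM in this assay. Compound 3 `Cc1cc(-c2nc3cc(F)ccc3o2)ccc1NC(=O)CN1CCN(CCCN(C)C)CC1` gives 11800 nM in this assay, the highest of the three numbers. Compound 4 `Cc1ccc2oc(-c3ccc(NC(=O)CN4CCN(CCCN(C)C)CC4)c(C)c3)nc2c1` has not been measured.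

Among the measured compounds shown here, the single change from compound 2 to compound 1 is methyl in place of fluoro on an aromatic carbon, and it made a 2.7-fold lower number from compound 2 to compound 1 (0.43 log units; beyond the scatter). The same change, at the same place, runs from compound 3 to compound 4: methyl in place of fluoro on an aromatic carbon. The difference between the core of compound 2 and the core of compound 3 is not broken down here; the two values simply show compound 3 with the higher number.

For the measured compounds named here, only one measured instance of the change exists, so the expectation leans on it alone. For compound 4 the expected step is a 2.7-fold lower number from compound 3 to compound 4 (0.43 log units; beyond the scatter). Going by the values given here, this rests on the single measured step of a 2.7-fold lower number from compound 2 to compound 1 (0.43 log units; beyond the scatter), applied to the number of compound 3, 11800 nM. Compound 4 is therefore estimated at 4400 nM in this assay, most likely between 2000 nM and 10000 nM.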

Compound 4, half-maximal inhibitory concentration: 7320 nM
Compound 4: the middle estimate sits 1.7-fold (0.22 log units) below what was measured; the measured number falls inside the stated range.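

In this assay, replacing 5-fluoro-1,3-benzoxazol-2-yl with 5-methyl-1,3-benzoxazol-2-yl gives a 1.6-fold lower number from compound 3 to compound 4 (0.21 log units; within the scatter), so on this core the step alone does not separate the methyl compound from the fluoro compound. Set beside the earlier step, the size of the change does not differ measurably between the two cores: the same change on two cores in this assay, a 2.7-fold lower number (0.43 log units; beyond the scatter) from compound 2 to compound 1 and a 1.6-fold lower number (0.21 log units; within the scatter) from compound 3 to compound 4, 1.7-fold (0.22 log units) apart, within the scatter of two such steps. This supports carrying the step across these two cores as a small effect of similar size, but it rests on two pairs only, and it does not show that the change would behave alike on any other core in the series or that its size is firmly fixed.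

The compounds shown leave open how chloro, methoxy or a plain hydrogen on the same aromatic carbon would compare with fluoro and methyl. They also leave open whether the step would stay the same size on a compound carrying a longer chain or a carboxylic acid elsewhere in the molecule.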